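Trifluoromethyl in Place of Chloro: Expected Potency of Compound 4

The compounds below may be only part of what the source reports. "The series", "measured", "known", "first", "only" and "open" are said of these compounds alone.

Measured so far:
Compound 1 `Cc1ccc(S(=O)(=O)c2nc3ccccc3nc2Nc2ccc(Cl)cc2)cc1`: 13800 nM
Compound 2 `Cc1ccc(S(=O)(=O)c2nc3ccccc3nc2Nc2ccc(C(F)(F)F)cc2)cc1`: 10300 nM
Compound 3 `O=S(=O)(c1ccc(Br)cc1)c1nc2ccccc2nc1Nc1ccc(Cl)cc1`: 11600 nM

These three compounds were tested in a functional assay on KB cells (Homo sapiens) for cytotoxicity, read by MTT assay, with a stated time of 72 h (on this read-out higher numbers stand for weaker inhibition and lower numbers for stronger inhibition), and all three gave numbers within the scatter of one another. Compound 4 `O=S(=O)(c1ccc(Br)cc1)c1nc2ccccc2nc1Nc1ccc(C(F)(F)F)cc1` has not yet been measured. Compound 2 differs from compound 1 by trifluoromethyl in place of chloro on an aromatic carbon, and this change gave a 1.3-fold lower number from compound 1 to compound 2 (0.13 log units; within the scatter). The cores of compound 3 and compound 1 differ by bromo in place of methyl on an aromatic carbon, a change that gave a 1.2-fold lower number from compound 1 to compound 3 (0.08 log units; within the scatter). Compound 4 differs from compound 3 by trifluoromethyl in place of chloro on an aromatic carbon, the same change seen once before, now made on the core of compound 3. For compound 4 a step of a 1.3-fold lower number from compound 3 to compound 4 (0.11 log units; within the scatter) is expected, resting on that single earlier instance and on the value of compound 3, 11600 nM. Compound 4 is therefore estimated at 9000 nM, with a likely range from 4500 nM to 18000 nM.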

Compound 4, half-maximal inhibitory concentration: > 50000 nM
Compound 4 ended at the assay's limit; the forecaster's own chance of this, stated with the estimate: 5%; middle value at least 5.5-fold (0.74 log units) away from the limit.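

In this assay compound 4 gave > 50000 nM, which is a limit of the assay and not a number. Trifluoromethyl in place of chloro gave an at least 4.3-fold higher number from compound 3 to compound 4 (0.63 log units; beyond the scatter), so this change did not carry over from the core of compound 1 to the core of compound 3: the same change on two cores in this assay, a 1.3-fold lower number (0.13 log units; within the scatter) from compound 1 to compound 2 and an at least 4.3-fold higher number (0.63 log units; beyond the scatter) from compound 3 to compound 4, at least 5.7-fold (0.76 log units) apart, beyond the scatter of two such steps Bromo in place of methyl gave an at least 4.8-fold higher number from compound 2 to compound 4 (0.68 log units; beyond the scatter), so it did not carry over either, though this does not show why the steps part or how large the true steps are: the same change on two cores in this assay, a 1.2-fold lower number (0.08 log units; within the scatter) from compound 1 to compound 3 and an at least 4.8-fold higher number (0.68 log units; beyond the scatter) from compound 2 to compound 4, at least 5.7-fold (0.76 log units) apart, beyond the scatter of two such steps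

The compounds shown leave open whether the result belongs only to bromo paired with trifluoromethyl. A nitrile or a methoxy group in place of trifluoromethyl on the core of compound 3 would test this.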